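The source may hold more compounds than are shown below. What is called first, only, known or untested is meant among the compounds shown, and "the series" means these compounds.

Measured compounds:
Compound 1 `COc1cc(-c2cc(/C=C/C(=O)c3ccc(N)cc3)[nH]n2)cc(OC)c1OC` — in a functional assay on A498 cells (Homo sapiens) for inhibition, read by sulforhodamine B assay, with a stated time of 48 h (on this read-out higher numbers stand for weaker inhibition of growth and lower numbers for stronger inhibition of growth), compound 1 gives 1640 nM.
Compound 2 `COc1ccc(C(=O)/C=C/c2cc(-c3cc(OC)c(OC)c(OC)c3)n[nH]2)cc1OC` — in this assay compound 2 gives 1480 nM.

Compound 1 cannot be set apart from compound 2 on these numbers, since the step of a 1.1-fold lower number from compound 1 to compound 2 (0.04 log units; within the scatter) lies within the scatter. Compound 3 `COc1cc(-c2cc(/C=C/C(=O)c3ccc(F)c(F)c3)[nH]n2)cc(OC)c1OC` differs from compound 1 by 3,4-difluorophenyl in place of 4-aminophenyl on a carbonyl carbon. Within the data shown here, the only measured step that bears on this change is the exchange of the same 4-aminophenyl for another aryl group on the carbonyl carbon, a 1.1-fold lower number from compound 1 to compound 2 (0.04 log units; within the scatter), which left the number essentially unchanged. Compound 3 is therefore expected to land close to compound 1, with a step of a 1.0-fold higher number from compound 1 to compound 3 (0.02 log units; within the scatter) not beyond the scatter. The estimate for compound 3 is 1700 nM, within 700 nM to 4200 nM.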

Compound 3, concentration for 50% growth inhibition: 2110 nM
Beside the measured number, compound 3's estimate is 1.2-fold (0.09 log units) below it; the measured number falls inside the stated range.
By their numbers in this assay, from the lowest: compounds 2, 1 and 3 (each within the scatter of the next).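

In this assay, 3,4-difluorophenyl on a carbonyl carbon stays within the scatter of both earlier groups, with a 1.3-fold higher number from compound 1 to compound 3 (0.11 log units; within the scatter) and a 1.4-fold higher number from compound 2 to compound 3 (0.15 log units; within the scatter). The three compounds therefore cannot be told apart at this position, even though 3,4-difluorophenyl, unlike 4-aminophenyl, counts no hydrogen-bond donor or acceptor. Nothing available here explains this result.

The compounds shown leave open whether any group at this position would move the number beyond the scatter. A carboxylic acid on the phenyl ring, or a methyl group in place of the ring, would test this.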